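The source may hold more compounds than are shown below. What is called first, only, known or untested is meant among the compounds shown, and "the series" means these compounds.

Measured in a functional assay on SW480 cells (Homo sapiens) for antiproliferative activity, with a stated time of 72 h; a higher number here means a weaker inhibitor, a lower number a stronger inhibitor:
Compound 1 `Cc1[nH]c2ccccc2c1C1=CCC(NC(=O)c2ccc(OCC(=O)NO)cc2)CC1`: > 5000 nM, a limit of the assay
Compound 2 `Cc1[nH]c2ccccc2c1C1=CCC(NCc2ccc(OCC(=O)NO)cc2)CC1`: 367 nM

Going by the values given here, compound 2 holds the only actual number so far, 367 nM. Compound 3 `Cc1[nH]c2ccccc2c1C1=CCC(NCc2ccc(OCC(=O)NO)cc2F)CC1` differs from it by fluoro in place of hydrogen on an aromatic carbon, ortho to a large group and meta to a (hydroxycarbamoyl)methoxy group. Among the compounds with values here, no measured pair tests this change, so no shift beyond the scatter is expected in this assay, in either direction. The expected change is a 1.2-fold lower number from compound 2 to compound 3 (0.09 log units; within the scatter). Compound 3 is estimated at 300 nM, with an expected range of 100 nM to 900 nM.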

Compound 3, half-maximal inhibitory concentration: 170 nM
The estimate for compound 3 lay 1.8-fold (0.25 log units) above the measured number, within the range that was stated.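

In this assay, fluoro in place of hydrogen on this aromatic carbon, ortho to a large group and meta to a (hydroxycarbamoyl)methoxy group, gives a 2.2-fold lower number from compound 2 to compound 3 (0.33 log units; beyond the scatter), so this position accepts a substituent and the number responds to it. The step is modest, but it lies beyond the scatter. It rests on this single pair, and nothing measured here explains it.

On these data alone, whether chloro, methyl or methoxy on the same carbon would move the number further remains open. So does whether fluoro on the other carbons of this ring would give a similar step.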